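A few compounds are considered here, and "the series" means these few. Any claim that something is new, unique, unknown or untested is made for them only; others in the source may bear on it.

Among the compounds with values here, compound 3, with the structure `O=C1N=C(N2CCC[C@H]2C(=O)Nc2ccc3ncnc(Nc4cccc(Cl)c4)c3c2)S/C1=C/c1ccccc1F`, is the lowest of the three numbers so far in a functional assay on HepG2 cells (Homo sapiens) for antiproliferative activity, read by MTT assay (a lower number here means a stronger inhibitor, a higher number a weaker inhibitor), though its steps to compound 2, structure `O=C1N=C(N2CCC[C@H]2C(=O)Nc2ccc3ncnc(Nc4cccc(Cl)c4)c3c2)S/C1=C/c1cccc(Br)c1`, and compound 1, structure `O=C1N=C(N2CCC[C@H]2C(=O)Nc2ccc3ncnc(Nc4cccc(Cl)c4)c3c2)S/C1=C/c1ccccc1Cl`, lie within the scatter. In this assay compound 3 gives 18200 nM, compound 2 gives 21300 nM and compound 1 gives 28100 nM.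

Compound 4, structure `O=C1N=C(N2CCC[C@H]2C(=O)Nc2ccc3ncnc(Nc4cccc(Cl)c4)c3c2)S/C1=C/c1ccc2ccccc2n1`, differs from compound 3 by quinolin-2-yl in place of 2-fluorophenyl on a double-bonded chain carbon bound to a double-bonded ring carbon. The measured steps all exchange one halogen-bearing phenyl for another at this same position: a 1.3-fold lower number from compound 1 to compound 2 (0.12 log units; within the scatter), a 1.5-fold lower number from compound 1 to compound 3 (0.19 log units; within the scatter) and a 1.2-fold lower number from compound 2 to compound 3 (0.07 log units; within the scatter), none beyond the scatter. Within the data shown here, no measured step replaces the single ring by a two-ring system, so those steps bear only indirectly, showing that this position tolerates change without a large shift. Compound 4 is therefore expected to land near its neighbours, with an expected step of a 1.2-fold lower number from compound 3 to compound 4 (0.08 log units; within the scatter) that may not exceed the scatter. The estimate for compound 4 is 15000 nM, within a range from 5000 nM to 45000 nM.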

Compound 4, half-maximal inhibitory concentration: 22900 nM
Compound 4: the middle estimate sits 1.5-fold (0.18 log units) below what was measured; measured number inside the range.
By their numbers in this assay, from the lowest: compounds 3, 2, 4 and 1 (each within the scatter of the next).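

Putting quinolin-2-yl, a two-ring group with a ring nitrogen and a hydrogen-bond acceptor, in place of a single halogen-bearing phenyl stays within the scatter in this assay against all three earlier compounds (a 1.3-fold higher number from compound 3 to compound 4 (0.10 log units; within the scatter)), (a 1.1-fold higher number from compound 2 to compound 4 (0.03 log units; within the scatter)) and (a 1.2-fold lower number from compound 1 to compound 4 (0.09 log units; within the scatter)). The earlier compounds shown here only exchanged one halogen-bearing phenyl for another, whereas this result shows that a larger group containing a ring nitrogen, on a double-bonded chain carbon bound to a double-bonded ring carbon, also leaves the number unmoved beyond the scatter. Nothing measured here gives a reason for this flat response.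

From the compounds shown here alone, all four compounds carry an aromatic group at this place, so it remains open whether a cyclohexyl ring, a longer alkyl chain or a phenyl bearing an amine or a carboxylic acid would shift the number beyond the scatter. Going by these compounds, it also remains open whether any group here could bring the number far below those seen so far.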